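Benzyl in Place of Methoxyphenyl on the Amide Nitrogen

The source may report more compounds than this note shows. Statements on the series, on what has been measured and on what is new or still open speak of the compounds shown alone.

Compound 1 `CCCCc1ccc(NC(=O)C2CCN(C/C=C/c3ccccc3)CC2)cc1`: 4320 nM
Compound 2 `COc1ccccc1NC(=O)C1CCN(C/C=C/c2ccccc2)CC1`: 91200 nM

In a functional assay on HepG2 cells (Homo sapiens) for inhibition, read by MTT assay, with a stated time of 72 h (on this read-out lower numbers stand for stronger inhibition and higher numbers for weaker inhibition), compound 2 gives the highest of the two numbers, with compound 1 standing far lower. Compound 3 `O=C(NCc1ccccc1)C1CCN(C/C=C/c2ccccc2)CC1` is not yet measured; it differs from compound 2 by benzyl in place of 2-methoxyphenyl on an amide-type nitrogen. For the measured compounds named here, no measured pair separated by a single change exists, so the size of this step can only be guessed. The two measured compounds already differ widely, and a downward move beyond the scatter appears more likely than none. Compound 3 is expected to give 20000 nM, within 4000 nM to 100000 nM. That expectation amounts to a step of a 4.6-fold lower number from compound 2 to compound 3 (0.66 log units; beyond the scatter).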

Compound 3, half-maximal inhibitory concentration: > 100000 nM
Compound 3: only a limit was reported (the forecaster's own chance of this, stated with the estimate: 10%); middle value at least 5.0-fold (0.69 log units) away from the limit.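

In this assay, benzyl in place of 2-methoxyphenyl on the amide-type nitrogen gives an at least 1.0-fold higher number from compound 2 to compound 3 (0.04 log units; that floor lies within the scatter). Compound 3 gives > 100000 nM, which is a limit of the assay and not a number. The swap therefore brings no stronger inhibition at this position, and the step can be read only as a floor because of that limit: the limit of > 100000 nM in this assay, at which 1 of the 3 values shown sits.

On these data alone, how far compound 3 truly lies from compound 2 stays open. Also open, as far as these compounds go, is whether a longer chain such as phenethyl on this nitrogen, or an amine on the benzyl ring, would bring the number down.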